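The source may report more compounds than this note shows. Statements on the series, on what has been measured and on what is new or still open speak of the compounds shown alone.

Series notes. Compound 1 `C#CCSc1nc2cc(Cl)c(Cl)cc2n1C1O[C@H](CO)[C@@H](O)[C@H]1O` gives 60000 nM in a functional assay on KB cells (Homo sapiens) for inhibition; on this read-out lower numbers stand for stronger inhibition and higher numbers for weaker inhibition. Compound 2 `COc1ccc(CSc2nc3cc(Cl)c(Cl)cc3n2C2O[C@H](CO)[C@@H](O)[C@H]2O)cc1` gives 41000 nM in this assay. Compound 3 `OC[C@H]1OC(n2c(SCc3ccccc3Cl)nc3cc(Cl)c(Cl)cc32)[C@H](O)[C@@H]1O` gives 30000 nM in this assay, the smallest of the three numbers, though its gaps to the other two both stay within the scatter: a 2.0-fold lower number from compound 1 to compound 3 (0.30 log units; within the scatter) and a 1.4-fold lower number from compound 2 to compound 3 (0.14 log units; within the scatter). For the measured compounds named here, every measured step so far alters the group on the saturated chain carbon bound to a sulfur, and none leaves the scatter; the remaining one reads a 1.5-fold lower number from compound 1 to compound 2 (0.17 log units; within the scatter).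

Compound 4 `OC[C@H]1OC(n2c(SCc3cccc(C(F)(F)F)c3)nc3cc(Cl)c(Cl)cc32)[C@H](O)[C@@H]1O` continues the same variation: 3-(trifluoromethyl)phenyl in place of 2-chlorophenyl on a saturated chain carbon bound to a sulfur. All three measured steps bear on this change, since each swaps one group on that same carbon for another, and none moved this assay by more than the scatter; exchanges at this carbon have left the read-out flat across compounds 1, 2 and 3. On that basis the expected step is no change at the digits printed from compound 3 to compound 4 (within the scatter), that is, nothing beyond the scatter in either direction. Compound 4 is expected to give about 30000 nM in this assay, with a range from 12000 nM to 75000 nM.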

Compound 4, half-maximal inhibitory concentration: 15000 nM
Beside the measured number, compound 4's estimate is 2.0-fold (0.30 log units) above it; low and high end bracket the measured number.
By their numbers in this assay, from the lowest: compounds 4, 3, 2 and 1 (each within the scatter of the next, the first and the last beyond it).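

For the compounds shown here, at the saturated chain carbon bound to a sulfur, exchanges now move this assay beyond the scatter for the first time, with 3-(trifluoromethyl)phenyl giving a 2.7-fold lower number from compound 2 to compound 4 (0.44 log units; beyond the scatter) against 4-methoxyphenyl and a 4.0-fold lower number from compound 1 to compound 4 (0.60 log units; beyond the scatter) against ethynyl, so the position is no longer flat across the whole set. The separation holds only at the ends of the series, however: against 2-chlorophenyl the change gives a 2.0-fold lower number from compound 3 to compound 4 (0.30 log units; within the scatter) and leaves compound 3 and compound 4 unordered, so 3-(trifluoromethyl)phenyl cannot be set apart from every other group tried here. No measurement at hand accounts for these steps.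

Because compound 3 and compound 4 differ in both the group on the aromatic ring and its place, the two contributions cannot be separated, and an unsubstituted phenyl on the same carbon would be the plainest reference for reading either one. As far as these compounds go, whether this carbon tolerates an amine, a carboxylic acid or a longer alkyl chain remains open, as does whether any change to the shared core would shift the read-out further than these exchanges have.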